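The source may report more compounds than this note shows. Statements on the series, on what has been measured and on what is new or still open speak of the compounds shown alone.

Measured compounds so far:
compound 1 `CCN(Cc1cccs1)C(=O)COc1ccc(F)cc1`
compound 2 `Cc1ccc(OCC(=O)N(Cc2cccs2)C(C)(C)C)cc1`
compound 3 `CCN(Cc1nccs1)C(=O)COc1ccc(C)cc1`

In an assay on HEK293 cells for agonist activity at transient receptor potential cation channel subfamily M member 8 (Homo sapiens), read by fluorescence and calcium flux, with a stated time of 15 min (on this read-out lower numbers stand for an effect already at smaller amounts and higher numbers for an effect only at larger amounts of compound), compound 1 gives 422 nM, compound 3 gives 3060 nM, and compound 2 gives 11000 nM. Compound 1 stands at the lowest number of the three; its nearest neighbour is compound 3, and the gap to it is beyond the scatter, as is the larger gap to compound 2. Compound 1 is therefore the most potent compound in this assay among those measured.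

The next compound, compound 4 `CCN(Cc1cccs1)C(=O)COc1ccc(C#N)cc1`, keeps the core of compound 1 and changes one group on the six-membered aromatic ring: cyano in place of fluoro on an aromatic carbon. For the measured compounds named here, no pair of measured compounds isolates this change, so nothing shows how this exchange, cyano in place of fluoro on an aromatic carbon, moves the read-out. Both groups sit at the same place, para to a large group, and compound 1 carries the lowest number in this assay, so the expected step from compound 1 to compound 4 is a 1.9-fold higher number from compound 1 to compound 4 (0.28 log units; within the scatter), a small rise that may still fall within the scatter.

For compound 4 the estimate in this assay is 800 nM, with a range from 200 nM to 3500 nM.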

Compound 4, half-maximal effective concentration: 1990 nM
For compound 4 the middle estimate is 2.5-fold (0.40 log units) below the measured one; low and high end bracket the measured number.
By their numbers in this assay, from the lowest: compound 1; then compounds 4 and 3 (each within the scatter of the next); then compound 2.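

In this assay, for the compounds shown here, the exchange at this aromatic carbon, para to a large group, gives the first step that isolates a single change: a 4.7-fold higher number from compound 1 to compound 4 (0.67 log units; beyond the scatter) with cyano in place of fluoro. Going by these compounds alone, the position is therefore not indifferent to the group it carries, since with the rest of the core of compound 1 held fixed, this one exchange moves the read-out beyond the scatter, though only modestly, and fluoro remains the group on the compound with the lowest number measured so far. Nothing available explains this step, so it stands as an observation on these two groups alone.

Steps involving compound 2 or compound 3 cannot be read, as each differs from compound 1 and from compound 4 in more than one place, so the methyl group they carry at this position has no clean comparison. On these data alone, whether chloro, methoxy, trifluoromethyl or an amine at this same carbon would give a number nearer that of compound 1 or that of compound 4, or one outside both, remains open, and two groups alone define no trend at this position.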